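Rearranging Eight Carbons on the Sulfonamide Nitrogen

The compounds below may be only part of what the source reports. "The series", "measured", "known", "first", "only" and "open" are said of these compounds alone.

Compound 1 `CCc1cccc(NS(=O)(=O)c2ccc(N3CCNC3=O)cc2)c1` was tested in a functional assay on DU-145 cells (Homo sapiens) for antiproliferative activity, read by sulforhodamine B assay, with a stated time of 48 h (on this read-out lower numbers stand for stronger inhibition and higher numbers for weaker inhibition), where compound 1 gives 730 nM. For the measured compounds named here, of the two numbers so far, this is the highest; the only other measured compound, compound 2 `COc1cc(NS(=O)(=O)c2ccc(N3CCNC3=O)cc2)cc(OC)c1OC`, gives in this assay a value of 51 nM, a gap that lies beyond the scatter. Going by the values given here, no step between measured compounds that differ in a single place is available, so the move to the unmeasured compound 3 `Cc1ccc(C)c(NS(=O)(=O)c2ccc(N3CCNC3=O)cc2)c1` rests on the structural change alone. The difference is 2,5-dimethylphenyl in place of 3-ethylphenyl on a sulfonamide nitrogen; the two compounds share every atom and differ only in how those atoms are joined. Among the compounds with values here, with no comparable step to lean on, one expects a step in this assay that stays within the usual scatter, in no particular direction. Compound 3 is therefore expected to give about 650 nM, with a range from 200 nM to 2000 nM, meaning an expected step of a 1.1-fold lower number from compound 1 to compound 3 (0.05 log units; within the scatter).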

Compound 3, half-maximal inhibitory concentration: 1610 nM
The estimate for compound 3 lay 2.5-fold (0.39 log units) below the measured number, within the range that was stated.
By their numbers in this assay, from the lowest: compound 2; then compound 1; then compound 3.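

In this assay, putting 2,5-dimethylphenyl in place of 3-ethylphenyl on a sulfonamide nitrogen gives a 2.2-fold higher number from compound 1 to compound 3 (0.34 log units; beyond the scatter) and this is a modest step. It is the first change shown at this position that can be read as a single step, and it shows that the read-out responds even when the group that leaves and the group that enters have the same count of 8 carbon atoms and one aromatic ring of carbon only. Nothing available explains why this rearrangement moves the number.

The compounds shown leave open how this position would respond to an amine, a carboxylic acid or a longer chain on the ring. They also leave open whether 2-methylphenyl or 3-methylphenyl alone would account for the step.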